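Salicylamide anilides against K562: valine and glycine linkers

The source may hold more compounds than are shown below. What is called first, only, known or untested is meant among the compounds shown, and "the series" means these compounds.

Measured so far:
compound 1 `CC(C)[C@H](NC(=O)c1ccc(Cl)cc1O)C(=O)Nc1ccc(Cl)c(Cl)c1` — > 10000 nM
compound 2 `O=C(CNC(=O)c1cc(Cl)ccc1O)Nc1ccc(Cl)c(Cl)c1` — > 20000 nM

In a functional assay on K562 cells (Homo sapiens) for cytotoxicity, with a stated time of 72 h (a higher number here means a weaker inhibitor, a lower number a stronger inhibitor), compound 1 gives only a limit, > 10000 nM. In this assay compound 2 likewise gives only a limit, > 20000 nM. Neither value is a number, so no ordering between compound 1 and compound 2 can be read; both sit at the edge of what the assay reports, as the limit of > 10000 nM in this assay, at which 1 of the 2 values shown sits, and the limit of > 20000 nM in this assay, at which 1 of the 2 values shown sits, record.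

Compound 3 `CC(C)[C@H](NC(=O)c1cc(Cl)ccc1O)C(=O)Nc1ccc(Cl)c(Cl)c1` has not been measured. It is reached from compound 2 by one change, (isopropyl in place of hydrogen on a saturated chain carbon bound to an amide-type nitrogen and a carbonyl carbon). In words: isopropyl in place of hydrogen on a saturated chain carbon bound to an amide-type nitrogen and a carbonyl carbon. For the measured compounds named here, no measured pair in this set isolates that change, so its size in this assay is not known from data here. Compound 1 carries the same isopropyl on the same chain carbon and also returns only a limit, which gives no sign that the isopropyl alone brings potency into the measurable range.

The expectation for compound 3 is therefore a value that stays at or near the reporting limit, with the step from compound 2 to compound 3 estimated as an at least 1.1-fold lower number from compound 2 to compound 3 (0.04 log units; that floor lies within the scatter), none beyond the scatter. Compound 3 is estimated at 18000 nM, within 5000 nM to 60000 nM.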

Compound 3, half-maximal inhibitory concentration: > 10000 nM
Compound 3: a limit, no number; the forecaster's own chance of this, stated with the estimate: 75%; the middle value lies beyond the limit too.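

In this assay compound 3 gives only a limit, > 10000 nM. For the compounds shown here, no step from compound 1 or compound 2 to compound 3 can be read, as all three values are limits. The compounds shown leave open whether isopropyl in place of hydrogen, or 5-chloro-2-hydroxyphenyl in place of 4-chloro-2-hydroxyphenyl, changes potency at all, and whether this series reaches a measurable value.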